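A few compounds are considered here, and "the series" means these few. Any claim that something is new, unique, unknown or untested is made for them only; others in the source may bear on it.

Compound 1 `CCCn1c(=O)c2nc(-c3cnn(Cc4ccc(F)cc4F)c3)[nH]c2n(CCC)c1=O` has no result in an assay on CHO cells for displacement of a labelled ligand from adenosine receptor A1 (Homo sapiens) (on this read-out higher numbers stand for weaker inhibition and lower numbers for stronger inhibition), where compound 1 is recorded as "not determined" (no result reported), so nothing can be said of it beyond its structure. Within the data shown here, compound 2 `CCCn1c(=O)c2nc(-c3cnn(Cc4cccc(Cl)c4)c3)[nH]c2n(CCC)c1=O` is the only compound with a number in this assay, where compound 2 gives 31 nM; it therefore stands alone, with no second number to set it against. Compound 3 `CCCn1c(=O)c2nc(-c3cnn(Cc4ccccc4C)c3)[nH]c2n(CCC)c1=O` carries 2-methylphenyl in place of 3-chlorophenyl on a saturated chain carbon bound to an aromatic nitrogen and has not yet been measured in this assay. Among the measured compounds shown here, no step between two measured compounds is available to guide the expectation, so any forecast rests on the shared core and on this single change alone. The step from compound 2 to compound 3 is expected to be modest, leaning towards weaker inhibition rather than stronger, with a 1.8-fold higher number from compound 2 to compound 3 (0.25 log units; within the scatter) as the expected size of that move. For compound 3 the estimate in this assay is 55 nM, within a range from 15 nM to 200 nM. The range is deliberately wide, as one measured compound gives little footing for how this assay responds to a change of this kind.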

Compound 3, inhibition constant: 22 nM
Compound 3: the middle estimate sits 2.5-fold (0.40 log units) above what was measured; the range from low to high includes it.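

In this assay, replacing 3-chlorobenzyl with 2-methylbenzyl gives a 1.4-fold lower number from compound 2 to compound 3 (0.15 log units; within the scatter), so this pair cannot be told apart on this read-out. The change swaps a chlorine for a methyl group and also moves the substituent around the phenyl ring, yet the read-out stays within its usual scatter, showing that on a saturated chain carbon bound to an aromatic nitrogen these two substituted phenyl groups are interchangeable as far as this single pair can show. Nothing in the available data bears on why the two compounds read alike.

Because the substituent's identity and its place on the ring change together, this pair cannot show what either change does alone, and a 3-methylphenyl or 2-chlorophenyl group would be needed to separate them. It also leaves open whether the same tolerance extends to an unsubstituted phenyl, to a phenyl ring carrying an amine or a carboxylic acid, or to a longer chain between the phenyl ring and the aromatic nitrogen.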